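A few compounds are considered here, and "the series" means these few. Any claim that something is new, unique, unknown or untested is made for them only; others in the source may bear on it.

Working notes on the series in an assay on CHO cells for agonist activity at 5-hydroxytryptamine receptor 1D (Homo sapiens), read by GTPgammaS binding; a lower number here means that less compound is needed, a higher number that more compound is needed for the effect. Compound 1 `O=S(=O)(NCC1CCN(CCCc2c[nH]c3ccc(-n4cnnc4)cc23)CC1)c1ccccc1` gives 12 nM in this assay. Among the measured compounds shown here, compound 2 `c1cc(CNC2CCN(CCCc3c[nH]c4ccc(-n5cnnc5)cc34)CC2)co1` gives 7.1 nM, the lowest of the two numbers recorded; its nearest neighbour is compound 1, and the only step at this position, a 1.7-fold lower number from compound 1 to compound 2 (0.23 log units; within the scatter), lies within the scatter, so the two compounds cannot be ordered against each other. Compound 3 `c1ccc2c(c1)CCC2NCC1CCN(CCCc2c[nH]c3ccc(-n4cnnc4)cc23)CC1` is not yet measured; it carries ((2,3-dihydro-1H-inden-1-yl)amino)methyl in place of ((furan-3-yl)methyl)amino on a saturated ring carbon. For the measured compounds named here, the one measured step that bears on this position, from compound 1 to compound 2, exchanged the whole substituent on the same saturated ring carbon without a change beyond the scatter, and nothing else in the set speaks to the present exchange. On that basis the step from compound 2 to compound 3 is expected to stay within the scatter, a 1.0-fold lower number from compound 2 to compound 3 (0.01 log units; within the scatter). Compound 3 is therefore estimated at 7 nM in this assay, within a range of 2.5 nM to 20 nM.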

Compound 3, half-maximal effective concentration: 1.3 nM
Estimate against measurement, compound 3: 5.4-fold (0.73 log units) above, outside the stated range (below it).
By their numbers in this assay, from the lowest: compound 3; then compounds 2 and 1 (each within the scatter of the next).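

In this assay, among the compounds shown here, the substituent on this saturated ring carbon now makes a difference: ((2,3-dihydro-1H-inden-1-yl)amino)methyl in place of ((furan-3-yl)methyl)amino brings a 5.5-fold lower number from compound 2 to compound 3 (0.74 log units; beyond the scatter) and is the first step beyond the scatter. With 2,3-dihydro-1H-inden-1-yl in place of phenylsulfonyl on an amine nitrogen, the series shows a 9.2-fold lower number from compound 1 to compound 3 (0.97 log units; beyond the scatter) as well, so the earlier pair, which could not be ordered, did not mean that the position tolerates any exchange equally. Nothing available gives a reason for either step.

The compounds shown do not separate the contribution of the fused carbon ring from that of the methyl link in ((2,3-dihydro-1H-inden-1-yl)amino)methyl. A benzylamino or cyclopentylamino group at this position, on the same methyl link or directly on the ring carbon, would address that question.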